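Notes on replacing 3,5-dichloro-4-hydroxyphenyl in compound 2

The source may report more compounds than this note shows. Statements on the series, on what has been measured and on what is new or still open speak of the compounds shown alone.

Measured in a functional assay on PANC-1 cells (Homo sapiens) for antiproliferative activity; a higher number here means a weaker inhibitor, a lower number a stronger inhibitor:
compound 1 `CC[C@H](C)[C@H]1C(=O)N[C@H](Cc2ccc(O)c(Br)c2)C(=O)N[C@@H](C(C)(C)O)C(=O)O[C@H](c2ccccc2)[C@H](C)/C=C/C=C(\C)[C@H](OC)C/C=C(\C)C(=O)N1C` gives 11.4 nM
compound 2 `CC[C@H](C)[C@H]1C(=O)N[C@H](Cc2cc(Cl)c(O)c(Cl)c2)C(=O)N[C@@H](C(C)C)C(=O)O[C@H](c2ccccc2)[C@H](C)/C=C/C=C(\C)[C@H](OC)C[C@@H]2O[C@@]2(C)C(=O)N1C` gives 15.5 nM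
compound 3 `CC[C@H](C)[C@H]1C(=O)N[C@H](Cc2cc(Cl)c(O)c(Cl)c2)C(=O)N[C@@H](C(C)C)C(=O)O[C@H](c2ccccc2)[C@H](C)/C=C/C=C(\C)[C@H](OC)C/C=C(\C)C(=O)N1C` gives 137 nM

Compound 2 at 15.5 nM stands within the scatter of compound 1 and beyond the scatter from compound 3 , whose number is higher. Compound 4 `CC[C@H](C)[C@H]1C(=O)N[C@H](Cc2ccc(O)c(Br)c2)C(=O)N[C@@H](C(C)C)C(=O)O[C@H](c2ccccc2)[C@H](C)/C=C/C=C(\C)[C@H](OC)C[C@@H]2O[C@@]2(C)C(=O)N1C` differs from compound 2 by one change: 3-bromo-4-hydroxyphenyl in place of 3,5-dichloro-4-hydroxyphenyl on a saturated chain carbon bound to a saturated ring carbon. Within the data shown here, no measured pair isolates this change. Compound 1 carries the same 3-bromo-4-hydroxyphenyl, differs elsewhere, and gives 11.4 nM, so no large loss is expected in this assay. No step beyond the scatter is expected, and the estimated step is a 1.4-fold lower number from compound 2 to compound 4 (0.15 log units; within the scatter). Compound 4 is estimated at 11 nM, with an expected range of 3.5 nM to 35 nM.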

Compound 4, half-maximal inhibitory concentration: 15.7 nM
Compound 4: middle estimate off by 1.4-fold (0.15 log units), on the low side; low and high end bracket the measured number.
By their numbers in this assay, from the lowest: compounds 1, 2 and 4 (each within the scatter of the next); then compound 3.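

In this assay, this change now has a direct reading: a 1.0-fold higher number from compound 2 to compound 4 (0.01 log units; within the scatter). With the rest of compound 2 held constant, 3-bromo-4-hydroxyphenyl and 3,5-dichloro-4-hydroxyphenyl cannot be told apart at this position, so replacing both chlorines with one bromine costs nothing measurable here. No available evidence accounts for this result. From the compounds shown here alone, it remains open whether the same swap reads alike on the core of compound 3 . Also open, going by these compounds, is how this position responds when an amine or a carboxylic acid replaces the halogen on the ring.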